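This account rests on a few compounds, and the source may have more. Where it says the series, first, only, none or still open, it means among the compounds named here.

Measured so far:
compound 1 `O=C(N/N=C/c1ccccc1)c1cccnc1Nc1cccc(C(F)(F)F)c1`: 53.9%
compound 2 `O=C(N/N=C/c1ccc(O)c(O)c1)c1cccnc1Nc1cccc(C(F)(F)F)c1`: 50.8%

In a functional assay on the whole organism (strain Wistar) for inhibition, with Rattus norvegicus as the target, read by paw edema, with a stated time of 1 h, at a dose of 10 mg/kg by the intraperitoneal route (a higher number here means more inhibition at the dose given (going by the name of the read-out), a lower number less inhibition), compound 2 stands lowest of the two numbers; its nearest neighbour is compound 1, and the step of a number 3.1 percentage points lower from compound 1 to compound 2 (within the scatter) lies within the scatter. Compound 3 `COc1cccc(/C=N/NC(=O)c2cccnc2Nc2cccc(C(F)(F)F)c2)c1` differs from compound 2 in one place: 3-methoxyphenyl in place of 3,4-dihydroxyphenyl on a carbon with a double bond to nitrogen. Among the compounds with values here, the only measured step that bears on this position is the one from compound 1 to compound 2, a swap of the ring on the same carbon, and it gave no change beyond the scatter. No step beyond the scatter is therefore expected in this assay for the change to compound 3. For compound 3 the expected value is 52%, with a range from 40% to 64%. This corresponds to an expected step of a number 1.2 percentage points higher from compound 2 to compound 3 (within the scatter).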

Compound 3, a percentage reported as inhibition, in the whole organism at one dose (the size of the read-out at that dose, not a potency): 58.8%
The estimate for compound 3 lay 6.8 percentage points below the measured number, within the range that was stated.
By their numbers in this assay, from the lowest: compounds 2, 1 and 3 (each within the scatter of the next).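

In this assay, 3-methoxyphenyl in place of 3,4-dihydroxyphenyl on the carbon with a double bond to nitrogen stays within the scatter (a number 8 percentage points higher from compound 2 to compound 3 (within the scatter)), so at this position the hydrogen-bond donors of the 3,4-dihydroxyphenyl group are not required for a reading in this range. Methoxy in place of hydrogen on an aromatic carbon of the phenyl group also stays within the scatter (a number 4.9 percentage points higher from compound 1 to compound 3 (within the scatter)). Nothing on hand bears on a cause for these steps.

Open, from the compounds shown here alone, is whether an amine or a carboxylic acid on this ring would give a step beyond the scatter.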